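Swapping the Ring on a Sulfonamide Nitrogen

The source may hold more compounds than are shown below. What is called first, only, known or untested is meant among the compounds shown, and "the series" means these compounds.

Two compounds share one core and differ only in the ring attached to a sulfonamide nitrogen. Compound 1 `O=S(=O)(CSc1nnc(Br)n1Cc1ccc(Br)c2ccccc12)Nc1ccccc1` carries a phenyl there, and in an assay on HEK293 cells for inhibition of solute carrier family 22 member 12 (Homo sapiens) (on this read-out higher numbers stand for weaker inhibition and lower numbers for stronger inhibition), compound 1 gives 15800 nM. Compound 2 `COc1ncccc1NS(=O)(=O)CSc1nnc(Br)n1Cc1ccc(Br)c2ccccc12` carries 2-methoxypyridin-3-yl instead, and in this assay compound 2 gives 4050 nM. Among the measured compounds shown here, of the two numbers measured so far, compound 2 has the lowest, and its nearest neighbour is compound 1; the step of a 3.9-fold lower number from compound 1 to compound 2 (0.59 log units; beyond the scatter) lies beyond the scatter. Compound 3 `O=S(=O)(CSc1nnc(Br)n1Cc1ccc(Br)c2ccccc12)Nc1ccc(Br)nc1` has not been measured and changes the same ring once more: 6-bromopyridin-3-yl in place of 2-methoxypyridin-3-yl on a sulfonamide nitrogen. For the measured compounds named here, the only measured step that bears on this change is a 3.9-fold lower number from compound 1 to compound 2 (0.59 log units; beyond the scatter), which shows that the ring on this nitrogen can shift the number by a modest amount. Going by the values given here, no measured pair shows what 6-bromopyridin-3-yl does or what losing 2-methoxypyridin-3-yl costs, so the direction is open. Compound 3 is expected to give 7500 nM in this assay, with a range from 2500 nM to 25000 nM. The expected step is a 1.9-fold higher number from compound 2 to compound 3 (0.27 log units; within the scatter), a move back toward compound 1.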

Compound 3, half-maximal inhibitory concentration: 2200 nM
Compound 3: middle estimate off by 3.4-fold (0.53 log units), on the high side; the whole stated range lies above it.
By their numbers in this assay, from the lowest: compounds 3 and 2 (each within the scatter of the next); then compound 1.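

Compound 3 shows that the methoxy group of compound 2 is not needed to keep the number low on this sulfonamide nitrogen. The step is a 1.8-fold lower number from compound 2 to compound 3 (0.27 log units; within the scatter), so in this assay the 6-bromopyridin-3-yl and 2-methoxypyridin-3-yl groups cannot be told apart, even though they carry different substituents on the ring. Measured against the phenyl of compound 1, the new group gives a 7.2-fold lower number from compound 1 to compound 3 (0.86 log units; beyond the scatter), so a second, different ring with one hetero atom also improves on phenyl, and none of the three compounds goes against that observation.

Nothing available here explains why these rings behave as they do. As far as these compounds go, what a plain pyridin-3-yl or a bromophenyl group would give on this nitrogen remains open, and with it whether the ring nitrogen, the bromine or both go with the lower number in compound 3.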